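This account rests on a few compounds, and the source may have more. Where it says the series, first, only, none or still open, it means among the compounds named here.

In a functional assay on KM12 cells (Homo sapiens) for inhibition, read by sulforhodamine B assay, with a stated time of 48 h (a higher number here means a weaker inhibitor, a lower number a stronger inhibitor), three compounds have been measured so far. Compound 1 (`O=C(Nc1cccc(-n2cc(-c3ccncc3)c(-c3ccc(Cl)c(O)c3)n2)c1)Nc1cccc(C(F)(F)F)c1`) gives 1330 nM, compound 2 (`COc1cc(-c2nn(-c3cccc(NC(=O)c4cccc(C(F)(F)F)c4)c3)cc2-c2ccncc2)ccc1Cl`) gives 1660 nM and compound 3 (`COc1cc(-c2nn(-c3cccc(NC(=O)Nc4ccc(Cl)c(Cl)c4)c3)cc2-c2ccncc2)ccc1Cl`) gives 810 nM. Compound 2 has the highest number of the three, although its gap to compound 1 lies within the scatter, while compound 3 stands clearly lower.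

Compound 4 (`COc1cc(-c2nn(-c3cccc(NC(=O)c4ccc(Cl)c(C(F)(F)F)c4)c3)cc2-c2ccncc2)ccc1Cl`) differs from compound 2 in one place: chloro in place of hydrogen on an aromatic carbon. The chloro sits ortho to a trifluoromethyl group and para to a large group, turning 3-(trifluoromethyl)phenyl into 4-chloro-3-(trifluoromethyl)phenyl.

Going by the values given here, only one measured step bears on this, and only loosely: a 2.0-fold lower number from compound 2 to compound 3 (0.31 log units; beyond the scatter). That modest step exchanges a whole group, so it does not isolate the effect of a single chloro. In this assay a smaller step towards a lower number is therefore expected, and it may not clear the scatter. The expected change is a 1.4-fold lower number from compound 2 to compound 4 (0.16 log units; within the scatter). The estimate for compound 4 is 1150 nM, with an expected range of 580 nM to 2300 nM.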

Compound 4, half-maximal inhibitory concentration: 2060 nM
Estimate against measurement, compound 4: 1.8-fold (0.25 log units) below, and the stated range covers the measured number.
By their numbers in this assay, from the lowest: compounds 3, 1, 2 and 4 (each within the scatter of the next, the first and the last beyond it).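

In this assay, chloro in place of hydrogen on an aromatic carbon, ortho to a trifluoromethyl group, gives a 1.2-fold higher number from compound 2 to compound 4 (0.09 log units; within the scatter), so this position accepts a chloro without a shift beyond the scatter. Exchanging the whole group on the carbonyl carbon gives a 2.5-fold higher number from compound 3 to compound 4 (0.41 log units; beyond the scatter), a modest step, so the added chloro alone does not reproduce the lower number of compound 3, which carries (3,4-dichlorophenyl)amino there. No measurement available here accounts for either result.

From the compounds shown here alone, whether a methoxy, an amine or a nitrile on this same aromatic carbon would read differently from the chloro remains open. Also open, going by these compounds, is whether the chloro gives a comparable step on the core of compound 1.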